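Chlorophenyl placement: from compound 3 to compound 4

A few compounds are considered here, and "the series" means these few. Any claim that something is new, unique, unknown or untested is made for them only; others in the source may bear on it.

Of the compounds shown here, three sharing one core have been measured, differing only in the halogen-bearing phenyl group. In a functional assay (a lower number here means a stronger inhibitor, a higher number a weaker inhibitor), compound 1 `CC(C)=CCOc1cc(O)c2c(c1)OC(c1ccccc1F)CC2=O` gives 5300 nM, compound 2 `CC(C)=CCOc1cc(O)c2c(c1)OC(c1ccc(F)cc1)CC2=O` gives 6060 nM, and compound 3 `CC(C)=CCOc1cc(O)c2c(c1)OC(c1ccccc1Cl)CC2=O` gives 4270 nM. Compound 3 stands with the other two, all within the scatter of one another, so no order among the three can be claimed.

The next compound is compound 4 `CC(C)=CCOc1cc(O)c2c(c1)OC(c1ccc(Cl)cc1)CC2=O`. The change is 4-chlorophenyl in place of 2-chlorophenyl on a saturated ring carbon, next to the ring oxygen.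

For the measured compounds named here, the closest precedent is the matching change among the fluoro compounds, 4-fluorophenyl in place of 2-fluorophenyl, which gave a 1.1-fold higher number from compound 1 to compound 2 (0.06 log units; within the scatter), within the scatter. Chloro in place of fluoro gave a 1.2-fold lower number from compound 1 to compound 3 (0.09 log units; within the scatter), also within the scatter, and the remaining pair gave a 1.4-fold lower number from compound 2 to compound 3 (0.15 log units; within the scatter), again within the scatter. Going by the values given here, this precedent rests on a single pair, and no pair of chloro compounds has yet been measured. The expected step is a 1.1-fold higher number from compound 3 to compound 4 (0.04 log units; within the scatter), with no shift beyond the scatter in either direction. For compound 4 the estimated value in this assay is 4700 nM, with an expected range of 2500 nM to 8500 nM.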

Compound 4, half-maximal inhibitory concentration: 7020 nM
Estimate against measurement, compound 4: 1.5-fold (0.17 log units) below; the range from low to high includes it.
By their numbers in this assay, from the lowest: compounds 3, 1, 2 and 4 (each within the scatter of the next).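

In this assay, 4-chlorophenyl in place of 2-chlorophenyl on the saturated ring carbon next to the ring oxygen gives a 1.6-fold higher number from compound 3 to compound 4 (0.22 log units; within the scatter), so this swap of halogen placement has now been read with chloro as well as with fluoro, and neither reading leaves the scatter. The change from 2-fluorophenyl to 4-chlorophenyl, which alters halogen and placement together, also stays inside it, at a 1.3-fold higher number from compound 1 to compound 4 (0.12 log units; within the scatter). Compound 4 also supplies a second reading of chloro in place of fluoro, a 1.2-fold higher number from compound 2 to compound 4 (0.06 log units; within the scatter), and the two readings of that change agree: the same change on two cores in this assay, a 1.2-fold lower number (0.09 log units; within the scatter) from compound 1 to compound 3 and a 1.2-fold higher number (0.06 log units; within the scatter) from compound 2 to compound 4, 1.4-fold (0.16 log units) apart, within the scatter of two such steps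

Since no step among these four compounds lies beyond the scatter, the series so far shows no measurable dependence on the identity or placement of the halogen on this phenyl group. Still open, going by these compounds, is whether any replacement at this position can move the number beyond the scatter, for example an amine or a carboxylic acid in place of the chloro on the phenyl ring, or a plain unsubstituted phenyl on the same saturated ring carbon.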